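Propyl to Phenyl: Expected Clearance of Compound 3

The compounds below may be only part of what the source reports. "The series", "measured", "known", "first", "only" and "open" are said of these compounds alone.

The measure here is an ADME assay on liver for metabolic stability, with Liver microsome (Homo sapiens) as the target, read by LC-MS, using microsomes; a lower number here means slower removal, a higher number faster removal of the compound. Compound 1, with the structure `CC(C)(C)[C@@H](O)C(=O)N1[C@@H]2C[C@@H]2C[C@H]1C(=O)NCc1cc(Cl)ccc1-n1cnnn1`, gives 54 mL.min-1.g-1 in this assay. Compound 2 has the structure `CCCC[C@@H](O)C(=O)N1N=CC[C@H]1C(=O)NCc1cc(Cl)ccc1-n1cnnn1` and shares the same chlorinated benzylamide bearing a tetrazole, but differs in its core and in its side chain. In this assay compound 2 is reported only as a limit, < 12 mL.min-1.g-1, so its true value is not known as a number. This means (the limit of < 12 mL.min-1.g-1 in this assay, at which 1 of the 2 values shown sits), and compound 2 therefore stands at the lower edge of what was measured.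

Compound 3, with the structure `O=C(NCc1cc(Cl)ccc1-n1cnnn1)[C@@H]1CC=NN1C(=O)[C@H](O)Cc1ccccc1`, has not yet been measured. It differs from compound 2 by phenyl in place of propyl on a saturated chain carbon, two bonds along the chain from a carbonyl carbon and an oxygen on a saturated carbon.

Without a measured pair carrying this same change, only the values of compound 1 and compound 2 can guide an expectation. The step expected is an at least 1.1-fold higher number from compound 2 to compound 3 (0.06 log units; that floor lies within the scatter), which is small and within the usual scatter. Nothing measured points to a particular direction. Compound 3 is expected to give 14 mL.min-1.g-1, with a range from 6 mL.min-1.g-1 to 35 mL.min-1.g-1.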

Compound 3, intrinsic clearance in microsomes: < 12 mL.min-1.g-1
Compound 3: a limit, no number; the forecaster's own chance of this, stated with the estimate: 40%; at least 1.1-fold (0.06 log units) between middle value and limit.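

No step from compound 2 to compound 3 can be read in this assay, because each of these two compounds is reported only as a limit and not as a number: the limit of < 12 mL.min-1.g-1 in this assay, at which 2 of the 3 values shown sit.

The compounds shown leave open whether phenyl in place of propyl changes the clearance at all, and if so, in which direction.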